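The source may hold more compounds than are shown below. What is called first, only, known or untested is meant among the compounds shown, and "the series" means these compounds.

Working notes on the series.

Compound 1 `N#CC1=C(NC(=O)C2CC2)N(c2ccc(S(N)(=O)=O)cc2)C2=C(C(=O)CCC2)C1c1ccc(Cl)cc1Cl` is the reference point. In a functional assay on Ehrlich cells (Mus musculus) for cytotoxicity, read by trypan blue exclusion, with a stated time of 2 h, tested at 50 ug/mL (a lower number here means a weaker effect, a higher number a stronger effect of the compound at the concentration tested), compound 1 gives 40%. Compound 2 `N#CC1=C(NC(=O)c2ccccc2)N(c2ccc(S(N)(=O)=O)cc2)C2=C(C(=O)CCC2)C1c1ccc(Cl)cc1Cl` gives 70%, and compound 3 `CN(C)c1ccc(/C=N/C2=C(C#N)C(c3ccc(Cl)cc3Cl)C3=C(CCCC3=O)N2c2ccc(S(N)(=O)=O)cc2)cc1` gives 30%. Among these three numbers compound 1 stands second highest: the step of a number 10 percentage points lower from compound 1 to compound 3 (within the scatter) stays within the scatter, so compound 1 and compound 3 cannot be ordered, while the step of a number 30 percentage points higher from compound 1 to compound 2 (beyond the scatter) stands beyond it.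

Compound 4 `CC(=O)CC(=O)NC1=C(C#N)C(c2ccc(Cl)cc2Cl)C2=C(CCCC2=O)N1c1ccc(S(N)(=O)=O)cc1` differs from compound 1 by one change: 2-oxopropyl in place of cyclopropyl on a carbonyl carbon. Among the measured compounds shown here, the only measured step at the same carbonyl carbon is a number 30 percentage points higher from compound 1 to compound 2 (beyond the scatter), a modest rise on exchanging the cyclopropyl for phenyl. The steps of a number 10 percentage points lower from compound 1 to compound 3 (within the scatter) and a number 40 percentage points lower from compound 2 to compound 3 (beyond the scatter) change a group on a double-bonded ring carbon and so bear only loosely on this exchange. For the measured compounds named here, a 2-oxopropyl is not a phenyl, and no measured step shows what such a chain does here, so the expectation is a step within the scatter, or at most a small rise: a number 5 percentage points higher from compound 1 to compound 4 (within the scatter) is the estimated step. Compound 4 is expected to give 45% in this assay, between 25% and 65%.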

Compound 4, a percentage reported as activity, at one concentration (the size of the read-out at that concentration, not a potency): 60%
Compound 4: the middle estimate sits 15 percentage points below what was measured; the range from low to high includes it.
By their numbers in this assay, from the lowest: compounds 3 and 1 (each within the scatter of the next); then compounds 4 and 2 (each within the scatter of the next).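

The exchange of cyclopropyl for 2-oxopropyl on the carbonyl carbon gives a number 20 percentage points higher from compound 1 to compound 4 (beyond the scatter) and so shows that a rise at this position does not need an aromatic ring, as the phenyl of compound 2 might have suggested. Between the two groups that raise the number, the step of a number 10 percentage points lower from compound 2 to compound 4 (within the scatter) leaves phenyl and 2-oxopropyl unordered in this assay, although one has a ring and the other none. The larger exchange on the double-bonded ring carbon reads a number 30 percentage points higher from compound 3 to compound 4 (beyond the scatter) and places the chain-bearing amide clearly apart from the imine-linked group of compound 3.

The compounds shown offer no evidence on the cause of these steps. On these data alone, what a plain propyl, a carboxylic acid or an amine on the carbonyl carbon would give in this assay remains open, as does the contribution of the ketone oxygen of 2-oxopropyl.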